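Replacing the fluoro group of compound 2 with hydrogen

This account rests on a few compounds, and the source may have more. Where it says the series, first, only, none or still open, it means among the compounds named here.

Compound 1 `COc1cc(C(=O)O)ccc1OCCCCOc1ccc(C(=O)CC(C)C)c(O)c1C`: 99%
Compound 2 `Cc1c(OCCCCOc2ccc(C(=O)O)cc2F)ccc(C(=O)CC(C)C)c1O`: 106%

Among the compounds with values here, in an ADME assay on a cell-free system (plasma, Rattus norvegicus) for metabolic stability, read by LC-MS, with a stated time of 60 min, tested at 100 uM (a higher number here means that more of the compound is left, a lower number that less of the compound is left), compound 2 stands within the usual scatter of compound 1, the only other compound measured, so the two cannot be ranked. The next compound to be measured is compound 3 `Cc1c(OCCCCOc2ccc(C(=O)O)cc2)ccc(C(=O)CC(C)C)c1O`, which has hydrogen in place of fluoro on an aromatic carbon. Within the data shown here, only one measured step bears on this change, and it also involves the fluoro group: a number 7 percentage points higher from compound 1 to compound 2 (within the scatter), with fluoro in place of methoxy on an aromatic carbon. Among the measured compounds shown here, that single step gives no sign of a real shift, although no measured step removes a substituent outright. No change beyond the scatter is therefore expected in this assay, and the estimated step is a number 5 percentage points lower from compound 2 to compound 3 (within the scatter). Compound 3 is expected at 101%, with an estimated range of 91% to 110%.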

Compound 3, percent of the compound remaining: 95%
Compound 3: middle estimate off by 6 percentage points, on the high side; the range from low to high includes it.
By their numbers in this assay, from the lowest: compounds 3, 1 and 2 (each within the scatter of the next, the first and the last beyond it).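

In this assay, the change on this aromatic carbon, ortho to a large group and meta to a carboxy group, now gives a step beyond the scatter: a number 11 percentage points lower from compound 2 to compound 3 (beyond the scatter), a modest one, with the 4-carboxy-2-fluorophenyl group giving way to 4-carboxyphenyl. Hydrogen in place of methoxy at the same carbon stays within the scatter, a number 4 percentage points lower from compound 1 to compound 3 (within the scatter), so among these compounds only the pair with fluoro and hydrogen separates, and compound 1 cannot be ranked against either compound 2 or compound 3. Nothing at hand explains why this one pair separates. Still open, from the compounds shown here alone, is how a chloro or a nitrile group on this carbon would compare with fluoro. Also open, going by these compounds, is whether the same step would appear with a methyl ester in place of the carboxy group.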